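Methyl to methoxy in a weakly antiproliferative series

The source may report more compounds than this note shows. Statements on the series, on what has been measured and on what is new or still open speak of the compounds shown alone.

Compound 1 `COc1ccc(N2C(=O)COc3ccc(-c4cnc(Cl)c(NS(=O)(=O)c5ccc(F)cc5)c4)cc32)cc1` gives 36000 nM in a functional assay on MCF7 cells (Homo sapiens) for antiproliferative activity, read by MTT assay, with a stated time of 72 h; on this read-out higher numbers stand for weaker inhibition and lower numbers for stronger inhibition.
Compound 3 `Cc1ccc(N2C(=O)COc3ccc(-c4cnc(Cl)c(NS(=O)(=O)c5ccc(F)cc5)c4)cc32)cc1` gives 32600 nM in this assay.
Compound 2 `Cc1ccc(N2C(=O)COc3ccc(-c4cnc5ccccc5c4)cc32)cc1` reaches only the limit of this assay, > 40000 nM, and no number is reported for it.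

Compounds 1 and 3 share one core and differ only in one group: methoxy in place of methyl on an aromatic carbon. This change gave a 1.1-fold higher number from compound 3 to compound 1 (0.04 log units; within the scatter), so the two values cannot be told apart in this assay. Compound 2 carries a different core, and the difference between the two cores is not broken down here. Compound 2 sits at the limit of the assay, (the limit of > 40000 nM in this assay, at which 1 of the 3 values shown sits), the only one of the three measured compounds to do so.

Compound 4 `COc1ccc(N2C(=O)COc3ccc(-c4cnc5ccccc5c4)cc32)cc1` has not yet been measured in this assay. It stands to compound 2 as compound 1 stands to compound 3: methoxy in place of methyl on an aromatic carbon. The place of the change is the same in both pairs, on an aromatic carbon of a six-membered aromatic ring of carbon only, para to a large group, so the change is the same one. On the first core this change gave a 1.1-fold higher number from compound 3 to compound 1 (0.04 log units; within the scatter), and on that basis a similarly small step is expected from compound 2 to compound 4, a step that the limit leaves unreadable from compound 2 to compound 4. Because compound 2 gives only a limit, > 40000 nM, the same outcome is the most likely report for compound 4. Compound 4 is therefore estimated at 45000 nM in this assay, between 25000 nM and 90000 nM.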

Compound 4, half-maximal inhibitory concentration: > 40000 nM
Compound 4: a limit, no number; the forecaster's own chance of this, stated with the estimate: 70%; the middle value is on the limit's open side.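

Compound 2 and compound 4 both sit at the limit of this assay, so the step between them, methoxy in place of methyl on an aromatic carbon, cannot be read: the limit of > 40000 nM in this assay, at which 2 of the 4 values shown sit.

The compounds shown leave open whether this change does anything at all on the core of compound 2, and what separates that core from the core of compound 1.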